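Working notes: from compound 3 to compound 4

The compounds below may be only part of what the source reports. "The series", "measured", "known", "first", "only" and "open" are said of these compounds alone.

Values in an ADME assay on L02 cells (Homo sapiens) for inhibition, read by CCK-8 assay, with a stated time of 48 h; a lower number here means a stronger inhibitor of growth, a higher number a weaker inhibitor of growth:
- compound 1 `CN1CCN(c2ccc(Nc3ncc(Cl)c(Nc4ccccc4)n3)nc2)CC1`: 7990 nM
- compound 2 `COc1ccc(CNc2nc(Nc3ccc(N4CCN(C)CC4)cn3)ncc2Cl)cc1`: 12900 nM
- compound 3 `Cc1cccc(Nc2nc(Nc3ccc(N4CCN(C)CC4)cn3)ncc2Cl)c1`: 6080 nM

Compound 3 stands at 6080 nM. It cannot be separated from compound 1, as shown by a 1.3-fold lower number from compound 1 to compound 3 (0.12 log units; within the scatter), but it does separate modestly from compound 2, with a 2.1-fold lower number from compound 2 to compound 3 (0.33 log units; beyond the scatter).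

Next is compound 4 `CCc1ccc(Nc2nc(Nc3ccc(N4CCN(C)CC4)cn3)ncc2Cl)cc1`, which carries 4-ethylphenyl in place of 3-methylphenyl on a nitrogen on an aromatic ring.

The closest measured change is methyl in place of hydrogen on an aromatic carbon, which stayed within the scatter. The larger exchange of 4-methoxybenzyl for phenyl, a 1.6-fold higher number from compound 1 to compound 2 (0.21 log units; within the scatter), also stayed within it. Only the exchange between compound 2 and compound 3 passed the scatter, and only just. Among the measured compounds shown here, no measured compound carries 4-ethylphenyl, so this is a thin basis. No step beyond the scatter is expected in this assay, and the estimated change is a 1.1-fold higher number from compound 3 to compound 4 (0.03 log units; within the scatter).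

For compound 4 the expected value is 6500 nM, with an estimated range from 3200 nM to 13000 nM.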

Compound 4, concentration for 50% growth inhibition: 12100 nM
Compound 4: the middle estimate sits 1.9-fold (0.27 log units) below what was measured, and the stated range covers the measured number.
By their numbers in this assay, from the lowest: compounds 3, 1, 4 and 2 (each within the scatter of the next, the first and the last beyond it).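

In this assay, 4-ethylphenyl on this nitrogen cannot be separated from 3-methylphenyl (a 2.0-fold higher number from compound 3 to compound 4 (0.30 log units; within the scatter)), nor from the unsubstituted phenyl (a 1.5-fold higher number from compound 1 to compound 4 (0.18 log units; within the scatter)). Among the compounds shown here, compound 4 also cannot be separated from the 4-methoxybenzyl compound (a 1.1-fold lower number from compound 2 to compound 4 (0.03 log units; within the scatter)), so it lies within the scatter of both members of the only pair that separates (a 2.1-fold lower number from compound 2 to compound 3 (0.33 log units; beyond the scatter)), and that single step gives no firm reading of this position. Nothing measured here accounts for these numbers.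

The step to compound 4 changes both the chain and its place on the ring, so 4-methylphenyl and 3-ethylphenyl would be needed to tell those two changes apart. From the compounds shown here alone, whether an amine or a carboxylic acid on this phenyl would give a step beyond the scatter also stays open.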